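Methyl for Chloro on the Pendant Phenyl Ring

The compounds below may be only part of what the source reports. "The series", "measured", "known", "first", "only" and "open" are said of these compounds alone.

Compound 2 `O=C(O)C[C@H](O)C[C@H](O)CCn1c(C(F)(F)F)nc(-c2ccc(F)cc2)c1-c1cccc(Cl)c1` gives 41 nM in an assay on microsomes from liver for inhibition of 3-hydroxy-3-methylglutaryl-coenzyme A reductase (Rattus norvegicus) (a lower number here means a stronger inhibitor, a higher number a weaker inhibitor), the highest of the two numbers in hand, though its nearest neighbour lies within the scatter. That neighbour, compound 1 `O=C(O)C[C@H](O)C[C@H](O)CCn1c(C(F)(F)F)nc(-c2ccc(F)cc2)c1-c1ccc(F)cc1`, gives 38 nM in this assay. The measured step was a 1.1-fold higher number from compound 1 to compound 2 (0.03 log units; within the scatter). Compound 3 `Cc1cccc(-c2c(-c3ccc(F)cc3)nc(C(F)(F)F)n2CC[C@@H](O)C[C@@H](O)CC(=O)O)c1` carries a (methyl in place of chloro on an aromatic carbon). Going by the values given here, only the step between these two aryl variants bears on this change, and it stayed within the scatter, so the expected step is a 1.1-fold higher number from compound 2 to compound 3 (0.04 log units; within the scatter), nothing beyond the scatter. Compound 3 is therefore estimated at 45 nM, between 20 nM and 100 nM.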

Compound 3, half-maximal inhibitory concentration: 74 nM
Beside the measured number, compound 3's estimate is 1.6-fold (0.22 log units) below it; low and high end bracket the measured number.
By their numbers in this assay, from the lowest: compounds 1, 2 and 3 (each within the scatter of the next).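

On an aromatic carbon, meta to a large group, methyl in place of chloro gives a 1.8-fold higher number from compound 2 to compound 3 (0.26 log units; within the scatter) and so shows that this exchange of one heavy atom for another also stays inside the scatter. Compared with the 4-fluorophenyl of compound 1, the 3-methylphenyl of compound 3 gives a 1.9-fold higher number from compound 1 to compound 3 (0.29 log units; within the scatter) and leaves all three aryl variants unseparated. No measurement in hand bears on the reason for these small steps. Going by these compounds, whether an amine, a methoxy group or a carboxylic acid at this place would give a step beyond the scatter remains open.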